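The source may report more compounds than this note shows. Statements on the series, on what has been measured and on what is new or still open speak of the compounds shown alone.

Measured compounds in an ADME assay on microsomes from liver (Homo sapiens) for metabolic stability, read by HPLC, using NADPH, with stated times of 5 min and 60 min, tested at 10 uM; on this read-out higher numbers stand for fast clearance and lower numbers for slow clearance:
compound 1 `CCS(=O)(=O)Nc1ccc(Oc2ccccc2)c(-c2cn(C)c(=O)c3[nH]ccc23)c1`: < 45 mL/min/kg
compound 2 `Cn1cc(-c2cc(C(N)=O)ccc2Oc2ccccc2)c2cc[nH]c2c1=O`: 48.3 mL/min/kg

The value of compound 1 in this assay is a limit of the assay and not a number, as noted under (the limit of < 45 mL/min/kg in this assay, at which 1 of the 2 values shown sits). For compound 1 only that limit is known, so its place among the numbers shown is not fixed. Among the measured compounds shown here, the single measured step, an at least 1.0-fold higher number from compound 1 to compound 2 (0.03 log units; that floor lies within the scatter), puts carbamoyl in place of (ethylsulfonyl)amino on an aromatic carbon; its floor lies within the scatter, and it offers no direction.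

Compound 3 `CCS(=O)(=O)Nc1ccc(Oc2ccc(C#N)cc2)c(-c2cn(C)c(=O)c3[nH]ccc23)c1` differs from compound 1 by cyano in place of hydrogen on an aromatic carbon, a cyano in place of hydrogen on an aromatic carbon of the phenoxy ring, para to a large group. For the measured compounds named here, no measured step touches the phenoxy ring, so nothing here reads directly on this change. The expectation for a step that the limit leaves unreadable from compound 1 to compound 3 is therefore no step beyond the scatter. Compound 3 is estimated at 35 mL/min/kg, with a range from 15 mL/min/kg to 65 mL/min/kg, and a fair chance that only a limit is reported again.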

Compound 3, clearance: 41.7 mL/min/kg
The estimate for compound 3 lay 1.2-fold (0.08 log units) below the measured number; low and high end bracket the measured number.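

No step from compound 1 to compound 3 can be read in this assay, because the result for compound 1 is a limit and not a number: the limit of < 45 mL/min/kg in this assay, at which 1 of the 3 values shown sits.

The compounds shown leave open whether phenoxy to 4-cyanophenoxy changes clearance at all: no pair differing in that place carries a number on both sides.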